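The compounds below may be only part of what the source reports. "The series", "measured", "known", "first", "only" and "open" are said of these compounds alone.

Compound 2 `CN(C)/C(=N/CCCCCn1nc(-c2ccccc2)ccc1=O)NC#N` and compound 1 `C/N=C(/NC#N)NCCCCCn1nc(-c2ccccc2)ccc1=O` share one core. In a functional assay on the whole organism (stomach) with Rattus norvegicus as the target (on this read-out higher numbers stand for an effect only at larger amounts of compound and lower numbers for an effect already at smaller amounts), compound 2 gives 81.5 mg/kg, and compound 1 gives 100 mg/kg; the step of a 1.2-fold lower number from compound 1 to compound 2 (0.09 log units; within the scatter) is within the scatter, so the two numbers are not separated. Compound 3 `CN(C)/C(=N/CCCCCCn1nc(-c2ccccc2)ccc1=O)NC#N` differs from compound 2 by a group of 9 heavy atoms (5 carbon, 4 nitrogen; no ring) in place of a group of 8 heavy atoms (4 carbon, 4 nitrogen; no ring), on a saturated chain carbon, five bonds along the chain from an aromatic nitrogen. For the measured compounds named here, no measured step touches this kind of change, since the only step known, from compound 1 to compound 2, concerns a different group. The step of a 1.0-fold lower number from compound 2 to compound 3 (0.01 log units; within the scatter) is therefore expected to stay within the scatter, and compound 3 is estimated at 80 mg/kg, in the range 40 mg/kg to 160 mg/kg.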

Compound 3, dose for half-maximal effect: 93.1 mg/kg
Compound 3: middle estimate off by 1.2-fold (0.07 log units), on the low side; low and high end bracket the measured number.
By their numbers in this assay, from the lowest: compounds 2, 3 and 1 (each within the scatter of the next).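

In this assay, putting the group of 9 heavy atoms in place of the group of 8 heavy atoms gives a 1.1-fold higher number from compound 2 to compound 3 (0.06 log units; within the scatter) and so leaves the number unresolved from its neighbour. Set against the group of 7 heavy atoms, the same group gives a 1.1-fold lower number from compound 1 to compound 3 (0.03 log units; within the scatter) and again stays unseparated, so all three groups at this position read alike. Nothing available offers an explanation for this result.
Going by these compounds, what stays open is whether a much longer chain, or an amine or a carboxylic acid on this saturated chain carbon, would move the number beyond the scatter.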